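The source may report more compounds than this note shows. Statements on the series, on what has been measured and on what is new or still open speak of the compounds shown alone.

Measured compounds in an ADME assay on isolated protein for inhibition of Amine oxidase [flavin-containing] A (Homo sapiens), read by fluorescence and Amplex Red, with stated times of 15 min and 20 min; a higher number here means a weaker inhibitor, a lower number a stronger inhibitor:
compound 1, `C#CCN(CCCCOc1ccc2ccc(=O)oc2c1)Cc1cccc(OC)c1`, giving 78600 nM
compound 2, `C#CCN(CCCCOc1ccc2ccc(=O)oc2c1)Cc1ccc(C)cc1`, giving 94500 nM
compound 3, `C#CCN(C)CCCOc1ccc2ccc(=O)oc2c1`, giving 36900 nM

Of these three, compound 3 gives the lowest number in this assay; its gaps to compound 1 and to compound 2 both lie beyond the usual scatter of repeated measurements. Compound 4, `C#CCN(C)CCCCOc1ccc2ccc(=O)oc2c1`, differs from compound 3 in one place: (methyl(propargyl)amino)methyl in place of methyl(propargyl)amino on a saturated chain carbon, three bonds along the chain from an oxygen on an aromatic ring. Read one bond further out, the same difference is (methyl(propargyl)amino)methyl to 2-(methyl(propargyl)amino)ethyl, so compound 4 simply carries one more chain carbon between the amine nitrogen and the aromatic oxygen.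

Within the data shown here, no measured step speaks directly to this change. Among the measured compounds shown here, the only step among the measured compounds, a 1.2-fold higher number from compound 1 to compound 2 (0.08 log units; within the scatter), swaps one aryl group for another and leaves the chain untouched. Compounds 1 and 2 do carry the longer chain, but they also differ from compound 3 in the group on the amine nitrogen, so their values cannot isolate the chain length. With nothing pointing either way, compound 4 is expected to sit close to compound 3, with a 1.0-fold higher number from compound 3 to compound 4 (0.00 log units; within the scatter). Compound 4 is therefore estimated at 37000 nM, within a range of 12000 nM to 110000 nM.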

Compound 4, half-maximal inhibitory concentration: 3280 nM
The estimate for compound 4 lay 11-fold (1.05 log units) above the measured number; measured number below the stated range.
By their numbers in this assay, from the lowest: compound 4; then compound 3; then compounds 1 and 2 (each within the scatter of the next).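

Among these compounds, the step at this position is large: in this assay, going from methyl(propargyl)amino to (methyl(propargyl)amino)methyl on the saturated chain carbon, which lengthens the chain, gives a clear shift (an 11-fold lower number from compound 3 to compound 4 (1.05 log units; beyond the scatter)), so chain length matters here in a way the earlier compounds could not reveal. The group on the saturated chain carbon bound to the amine nitrogen also matters, which the swap between the two aryl groups (a 1.2-fold higher number from compound 1 to compound 2 (0.08 log units; within the scatter)) had not shown, since that swap stayed within the scatter: hydrogen in place of 4-methylphenyl (a 29-fold lower number from compound 2 to compound 4 (1.46 log units; beyond the scatter)) and hydrogen in place of 3-methoxyphenyl (a 24-fold lower number from compound 1 to compound 4 (1.38 log units; beyond the scatter)) are both large steps. Nothing available here accounts for the size of these steps.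

Among the compounds shown here, with only two chain lengths among compounds 3 and 4, it remains open whether a still longer chain would continue the same direction or reverse it. From the compounds shown here alone, it is also open how a plain phenyl group, or an ethyl group in place of the methyl on the amine nitrogen, would fare on the chain of compound 4.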